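A few compounds are considered here, and "the series" means these few. Any claim that something is new, unique, unknown or untested is made for them only; others in the source may bear on it.

Measured compounds:
- compound 1 `CCCCc1ccc2[nH]c(-c3ccc(OC)cc3)c(/C=N/O)c2c1`: 212 nM
- compound 2 `CCCCc1ccc2[nH]c(-c3ccc(C(F)(F)F)cc3)c(/C=N/NC(=O)c3ccncc3)c2c1`: 100 nM
- compound 3 `CCCCc1ccc2[nH]c(-c3ccc(CC)cc3)c(/C=N/NC(=O)c3ccncc3)c2c1`: 150 nM

In a functional assay on MCF7 cells (Homo sapiens) for antiproliferative activity, with a stated time of 5 days (a higher number here means a weaker inhibitor, a lower number a stronger inhibitor), compound 1 stands highest of the three numbers. Its nearest neighbour is compound 3, whose value lies within the scatter of that of compound 1; compound 2 sits further away, beyond the scatter.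

The step to the unmeasured compound 4 `CCCCc1ccc2[nH]c(-c3ccc(OC)cc3)c(/C=N/NC(=O)c3cccnc3)c2c1` is ((pyridin-3-yl)carbonyl)amino in place of hydroxy on a double-bonded nitrogen. For the measured compounds named here, no measured step covers this change. Going by the values given here, the only step on record, a 1.5-fold higher number from compound 2 to compound 3 (0.18 log units; within the scatter), concerns a change on the aromatic carbon and lies within the scatter, so it says nothing about the double-bonded nitrogen. Compound 2 and compound 3 both carry a substituent other than hydroxy on the double-bonded nitrogen and both give lower numbers than compound 1, but they differ from compound 1 on the aromatic carbon as well, so the two changes cannot be separated.

A modest downward step is therefore expected, a 1.8-fold lower number from compound 1 to compound 4 (0.25 log units; within the scatter), with a real chance of none beyond the scatter. Compound 4 is estimated at 120 nM, with a range from 50 nM to 300 nM.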

Compound 4, half-maximal inhibitory concentration: 75 nM
Beside the measured number, compound 4's estimate is 1.6-fold (0.20 log units) above it; the range from low to high includes it.
By their numbers in this assay, from the lowest: compounds 4, 2, 3 and 1 (each within the scatter of the next, the first and the last beyond it).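

In this assay, for the compounds shown here, ((pyridin-3-yl)carbonyl)amino in place of hydroxy on the double-bonded nitrogen gives a 2.8-fold lower number from compound 1 to compound 4 (0.45 log units; beyond the scatter), the first reading of this position with the rest of the core of compound 1 unchanged; compound 2 and compound 3 differ from compound 1 in a second place as well. The position therefore accepts a much larger group carrying a six-membered aromatic ring, and the number falls beyond the scatter. Nothing measured here bears on the reason for this fall.

As far as these compounds go, it remains open whether the aromatic ring, its ring nitrogen or the carbonyl-amino link accounts for the step. Benzoylamino, a plain amine or an acetylamino group on the double-bonded nitrogen would separate these parts, and a shorter chain in place of butyl would test the other end of the series.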